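Working notes on a cytotoxicity screen; compound 4 pending

The source may report more compounds than this note shows. Statements on the series, on what has been measured and on what is new or still open speak of the compounds shown alone.

Measured so far:
compound 1 `COc1ccc(-c2cnc(NC(=O)c3cnc[nH]3)n2C)cc1` — > 100000 nM
compound 2 `COc1ccc(-c2cnc(NC(=O)c3ccc(F)cc3)n2C2CCCC2)cc1` — > 100000 nM
compound 3 `COc1ccc(-c2cnc(NC(=O)c3cc(-c4ccccn4)n[nH]3)n2C)cc1` — >= 50000 nM

In a toxicity assay on THP-1 cells (Homo sapiens) for inhibition (on this read-out higher numbers stand for lower toxicity in this test and lower numbers for higher toxicity in this test), compound 1 gives > 100000 nM, which is a limit of the assay and not a number. Compound 2 also gives > 100000 nM in this assay, again a limit. Compound 3 gives >= 50000 nM, once more a limit rather than a measured value. Compound 1 thus stands at the limit of > 100000 nM in this assay, at which 2 of the 3 values shown sit, while compound 3 sits at the limit of >= 50000 nM in this assay, at which 1 of the 3 values shown sits. Among the compounds with values here, no pair among the three measured compounds differs in a single place, so no measured step can be described, and the three results show only that none of them reached a measurable cytotoxic concentration in this assay.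

Compound 4 `COc1ccc(-c2cnc(NC(=O)c3ccccc3Br)n2C)cc1` has not yet been measured in this assay. Relative to compound 1 the change is 2-bromophenyl in place of 1H-imidazol-5-yl on a carbonyl carbon. Since every measured compound sits at a limit, there is no evidence that any variation of the amide substituent so far moved toxicity into the measurable range, and the step from compound 1 to compound 4 is expected to be none beyond the scatter, as a number no higher from compound 1 to compound 4 (the limit leaves the size open). Compound 4 is expected to give about 100000 nM in this assay, in the range 40000 nM to 300000 nM, most likely reported again as a limit.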

Compound 4, half-maximal cytotoxic concentration: > 100000 nM
Compound 4 gave a limit, no number; the forecaster's own chance of this, stated with the estimate: 70%; the middle value sits exactly at the limit.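

No step can be read between compound 1 and compound 4: both results are limits of the assay, not numbers. The compounds shown leave open how far any of them lies past its limit in this assay, and whether 2-bromophenyl and 1H-imidazol-5-yl on a carbonyl carbon differ at all there.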